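The source may report more compounds than this note shows. Statements on the series, on what has been measured and on what is new or still open speak of the compounds shown alone.

Of the compounds shown here, two sharing one core have been tested for their ability to slow the growth of cultured cells. Compound 1 `CC1CCCCN1C(=S)SCc1ccc(C(=O)Nc2ccccc2N)cc1` carries a methyl-bearing saturated ring on the sulfur-containing linker; in a functional assay on HeLa cells (Homo sapiens) for antiproliferative activity, read by CCK-8 assay, with a stated time of 72 h, tested at 8 uM (a higher number here means a stronger effect of the compound at the concentration tested, a lower number a weaker effect), compound 1 gives 76.3%. Compound 2 `COc1ccc(N2CCN(C(=S)SCc3ccc(C(=O)Nc4ccccc4N)cc3)CC2)cc1` carries instead a six-membered ring with two nitrogens, one of them bearing a 4-methoxyphenyl group; in this assay compound 2 gives 52.3%. This is the lower of the two numbers, and the gap up to compound 1 lies beyond the usual scatter of such measurements.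

Compound 3 `Nc1ccccc1NC(=O)c1ccc(CSC(=S)N2CCN(c3ccccc3F)CC2)cc1` has not yet been measured. It differs from compound 2 in one place: 2-fluorophenyl in place of 4-methoxyphenyl on an amine nitrogen in a ring. Going by the values given here, no measured pair shows a change of this kind, so there is nothing to lean on except the two values in hand. The step from compound 2 to compound 3 is therefore expected to be small, with no firm direction, and is estimated as a number 2.7 percentage points higher from compound 2 to compound 3 (within the scatter). Compound 3 is expected to give about 55% in this assay, with a likely range from 35% to 75%.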

Compound 3, a percentage reported as inhibition, at one concentration (the size of the read-out at that concentration, not a potency): 59.2%
For compound 3 the middle estimate is 4.2 percentage points below the measured one, and the stated range covers the measured number.
By their numbers in this assay, from the lowest: compounds 2 and 3 (each within the scatter of the next); then compound 1.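

In this assay the exchange of 4-methoxyphenyl for 2-fluorophenyl on the amine nitrogen in the ring gives a number 6.9 percentage points higher from compound 2 to compound 3 (within the scatter) and so compound 2 and compound 3 cannot be told apart by this measurement. Going by these compounds alone, this is the first direct look at this position, and it shows that the read-out stays within the scatter when one substituted phenyl group replaces the other, even though the exchange swaps an oxygen-containing group for a fluorine and removes the one hydrogen-bond acceptor counted in the group that leaves. No separate measurement is available to explain this outcome or to link it to any feature of either group.

A single exchange that keeps a phenyl ring in place says little about how much freedom this position has overall, since both groups are six-membered aromatic rings of carbon only. The compounds shown leave open how the read-out would respond to a plain phenyl group, to a methyl group or an acetyl group on that same nitrogen, or to a phenyl ring carrying a carboxylic acid.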